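Lengthening the Ester Chain on Compound 2

A few compounds are considered here, and "the series" means these few. Any claim that something is new, unique, unknown or untested is made for them only; others in the source may bear on it.

In a functional assay on CCRF-CEM cells (Homo sapiens) (on this read-out lower numbers stand for higher toxicity in this test and higher numbers for lower toxicity in this test), compound 2 `COC(=O)CNC1=CS(=O)(=O)O[C@@]12[C@@H](CO[Si](C)(C)C(C)(C)C)O[C@@H](n1cc(C)c(=O)n(C)c1=O)[C@@H]2O[Si](C)(C)C(C)(C)C` gives 96000 nM, the highest of the three measured numbers. Compound 1 `Cc1cn([C@@H]2O[C@H](CO[Si](C)(C)C(C)(C)C)[C@@]3(OS(=O)(=O)C=C3NCC(=O)C(=O)N3CCC3)[C@H]2O[Si](C)(C)C(C)(C)C)c(=O)n(C)c1=O` gives 21600 nM, and compound 3 `CCOC(=O)CNC(=O)NC1=CS(=O)(=O)O[C@@]12[C@@H](CO[Si](C)(C)C(C)(C)C)O[C@@H](n1cc(C)c(=O)n(C)c1=O)[C@@H]2O[Si](C)(C)C(C)(C)C` gives 5020 nM. Compound 4 `Cc1cn([C@@H]2O[C@H](CO[Si](C)(C)C(C)(C)C)[C@@]3(OS(=O)(=O)C=C3NCCC(=O)OCc3ccccc3)[C@H]2O[Si](C)(C)C(C)(C)C)c(=O)n(C)c1=O` differs from compound 2 in one place only: (benzyloxycarbonyl)methyl in place of methoxycarbonyl on a saturated chain carbon bound to an amine nitrogen. Among the compounds with values here, no measured step alters this same chain, so the only guidance comes from changes elsewhere on the shared core, namely a 4.4-fold higher number from compound 1 to compound 2 (0.65 log units; beyond the scatter) and a 19-fold lower number from compound 2 to compound 3 (1.28 log units; beyond the scatter), both beyond the scatter and of modest to large size. With compound 2 standing at the top, a modest move downward is expected, so the step of a 2.4-fold lower number from compound 2 to compound 4 (0.38 log units; beyond the scatter) is the estimate. Compound 4 is therefore expected to give about 40000 nM, most likely between 12000 nM and 130000 nM.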

Compound 4, half-maximal cytotoxic concentration: > 250000 nM
Compound 4: no number, only a limit; the forecaster's own chance of this, stated with the estimate: 10%; middle value at least 6.2-fold (0.79 log units) from the limit.
By their numbers in this assay, from the lowest: compound 3; then compound 1; then compound 2. At a limit, above all of these: compound 4.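

In this assay compound 4 gives no number, only a limit: the limit of > 250000 nM in this assay, at which 1 of the 4 values shown sits.

Placing (benzyloxycarbonyl)methyl in place of methoxycarbonyl on this saturated chain carbon gives an at least 2.6-fold higher number from compound 2 to compound 4 (0.41 log units; beyond the scatter), the first evidence that this chain can move the read-out, and upward. The wider gaps, an at least 11-fold higher number from compound 1 to compound 4 (1.06 log units; beyond the scatter) and an at least 49-fold higher number from compound 3 to compound 4 (1.69 log units; beyond the scatter), put compound 4 beyond every number shown.

The compounds shown leave open whether the added chain length or the six-membered aromatic ring carries this step, and how far past its limit compound 4 lies. A 2-(methoxycarbonyl)ethyl group or a carboxylic acid on this chain would help separate these.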